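Methoxy in Place of Chloro: Expected Activity of Compound 4

The compounds below may be only part of what the source reports. "The series", "measured", "known", "first", "only" and "open" are said of these compounds alone.

Compound 1, `COc1ccc(NC(=O)Nn2c(-c3ccccc3)nc3ccccc3c2=O)cc1`, gives 52% in a functional assay on the whole organism (strain albino) with Mus musculus as the target, at a dose of 100 mg/kg by the intraperitoneal route; on this read-out higher numbers stand for more inhibition at the one dose given (going by the name of the read-out) and lower numbers for less inhibition.
Compound 2, `O=C(Nc1ccc(Cl)cc1)Nn1c(-c2ccccc2)nc2ccccc2c1=O`, gives 55% in this assay.
Compound 3, `CCc1nc2ccccc2c(=O)n1NC(=O)Nc1ccc(Cl)cc1`, gives 52% in this assay.

The three measured compounds share a common core and differ in two places. From compound 2 to compound 1 the difference is methoxy in place of chloro on an aromatic carbon, and in this assay this gave a number 3 percentage points lower from compound 2 to compound 1 (within the scatter). From compound 2 to compound 3 the cores differ by ethyl in place of phenyl on an aromatic carbon, and in this assay this gave a number 3 percentage points lower from compound 2 to compound 3 (within the scatter). Compound 3 and compound 1 thus stand level at the digits reported, and all three values lie within the scatter of one another.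

Compound 4, `CCc1nc2ccccc2c(=O)n1NC(=O)Nc1ccc(OC)cc1`, has not yet been measured. It differs from compound 3 by methoxy in place of chloro on an aromatic carbon. This is the same change as that from compound 2 to compound 1, made here on the core of compound 3; among the compounds shown it occurs twice in all. Among the compounds with values here, since the one earlier instance, a number 3 percentage points lower from compound 2 to compound 1 (within the scatter), stayed within the scatter, compound 4 is expected to give a number 2 percentage points lower from compound 3 to compound 4 (within the scatter) in this assay. Accordingly compound 4 is estimated to give 50% in this assay, with the range 38% to 62% reflecting the usual spread of such measurements. This expectation rests on one earlier step only, on a different core, and should be read as provisional.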

Compound 4, a percentage reported as inhibition, in the whole organism at one dose (the size of the read-out at that dose, not a potency): 48%
For compound 4 the middle estimate is 2 percentage points above the measured one, and the stated range covers the measured number.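

With a step of a number 4 percentage points lower from compound 3 to compound 4 (within the scatter) in this assay, methoxy in place of chloro behaved on the core of compound 3 as it had on the core of compound 1, so that on these two cores the change can be carried across without a visible difference: the same change on two cores in this assay, a number 3 percentage points lower (within the scatter) from compound 2 to compound 1 and a number 4 percentage points lower (within the scatter) from compound 3 to compound 4, 1 percentage points apart, within the scatter of two such steps

The other single change in the set, ethyl in place of phenyl, gave a number 4 percentage points lower from compound 1 to compound 4 (within the scatter) and read alike whether the aromatic ring bore 4-methoxyphenyl's methoxy or 4-chlorophenyl's chloro: the same change on two cores in this assay, a number 3 percentage points lower (within the scatter) from compound 2 to compound 3 and a number 4 percentage points lower (within the scatter) from compound 1 to compound 4, 1 percentage points apart, within the scatter of two such steps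

Within the data shown here, every one of these steps lies within the scatter, so the agreement shows only that neither change moved the number measurably on these compounds, not that either change has a reproducible effect of its own, and four compounds forming a single square cannot show that it would hold on any further core.

The compounds shown leave open whether other groups in the place of chloro and methoxy, such as an amine or a carboxylic acid, or a longer chain in the place of ethyl, would give a step beyond the scatter. Going by these compounds, they also offer a single read-out at one dose, which is not a potency, so how these compounds would compare across doses remains unknown.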